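Triazolylmethyl on the ring nitrogen of a piperidine ether

The source may hold more compounds than are shown below. What is called first, only, known or untested is meant among the compounds shown, and "the series" means these compounds.

Compound 2 `C[C@H](O[C@H]1CCCN[C@H]1c1ccccc1)c1cc(Cl)cc(Cl)c1` and compound 1 `C[C@H](O[C@H]1CCCN[C@H]1c1ccccc1)c1cc(C(F)(F)F)cc(C(F)(F)F)c1` share one core and differ in the substituents on the pendant aryl ring. In a functional assay on microsomes from liver for antagonist activity at Substance-P receptor (Rattus norvegicus) (on this read-out lower numbers stand for stronger inhibition and higher numbers for weaker inhibition), compound 2 gives 85 nM and compound 1 gives 87 nM; the two numbers lie within the scatter of each other, so no order between them is claimed. Compound 3 `C[C@H](O[C@H]1CCCN(Cc2n[nH]c(O)n2)[C@H]1c1ccccc1)c1cc(Cl)cc(Cl)c1` has not yet been measured. It carries (5-hydroxy-1H-1,2,4-triazol-3-yl)methyl in place of hydrogen on an amine nitrogen in a ring. Going by the values given here, no measured pair tells what this change does, so the expected step from compound 2 to compound 3 in this assay is a 2.1-fold lower number from compound 2 to compound 3 (0.33 log units; beyond the scatter), a modest move toward stronger inhibition with wide uncertainty. For compound 3 the expected value is 40 nM, in the range 10 nM to 200 nM.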

Compound 3, half-maximal inhibitory concentration: 25 nM
Beside the measured number, compound 3's estimate is 1.6-fold (0.20 log units) above it, within the range that was stated.
By their numbers in this assay, from the lowest: compound 3; then compounds 2 and 1 (each within the scatter of the next).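

The ring nitrogen of the shared core accepts a substituent: in this assay, (5-hydroxy-1H-1,2,4-triazol-3-yl)methyl in place of hydrogen gives a 3.4-fold lower number from compound 2 to compound 3 (0.53 log units; beyond the scatter), a modest step beyond the scatter. Hydrogen on this amine nitrogen is therefore not needed for inhibition in this series, which compound 1 and compound 2 alone could not show. Nothing at hand explains the step. Open, going by these compounds, is whether a plain methyl or a carboxylic acid on a methylene at this nitrogen would give a similar step. Also open, on these data alone, is whether the same substituent acts alike on the trifluoromethyl aryl ring of compound 1.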